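Lactone series: methylation of the ring hydroxyl

The source may hold more compounds than are shown below. What is called first, only, known or untested is meant among the compounds shown, and "the series" means these compounds.

Compound 1 `O=C1C[C@H]2O[C@H]([C@H](O)c3ccccc3)[C@H](O)[C@H]2O1` gives 18500 nM in a functional assay on Raji cells (Homo sapiens) for inhibition, read by MTT assay, with a stated time of 72 h; a higher number here means a weaker inhibitor, a lower number a stronger inhibitor. Compound 3 `CO[C@@H]1[C@H]2OC(=O)C[C@H]2O[C@@H]1[C@H](O)c1ccccc1` differs from it by methyl in place of hydrogen on an oxygen on a saturated carbon and gives 8690 nM, a step of a 2.1-fold lower number from compound 1 to compound 3 (0.33 log units; beyond the scatter). Compound 2 `CO[C@@H](c1ccccc1)[C@H]1O[C@@H]2CC(=O)O[C@@H]2[C@H]1O` gives 21100 nM; the difference between the core of compound 2 and the core of compound 1 is not broken down here. Compound 4 `CO[C@@H]1[C@H]2OC(=O)C[C@H]2O[C@@H]1[C@@H](OC)c1ccccc1` differs from compound 2 by methyl in place of hydrogen on an oxygen on a saturated carbon, the same change as from compound 1 to compound 3, made at the same place. Going by the values given here, only one earlier instance of this change is known, so the expectation rests on that single step. From compound 2 to compound 4 a step of a 2.1-fold lower number from compound 2 to compound 4 (0.32 log units; beyond the scatter) is expected in this assay, because the same change gave a 2.1-fold lower number from compound 1 to compound 3 (0.33 log units; beyond the scatter). Compound 4 is therefore estimated at 10000 nM, with a likely range from 5000 nM to 21000 nM.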

Compound 4, half-maximal inhibitory concentration: 10500 nM
For compound 4 the middle estimate is 1.1-fold (0.02 log units) below the measured one, within the range that was stated.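

In this assay, hydroxy to methoxy on the core of compound 2 gives a 2.0-fold lower number from compound 2 to compound 4 (0.30 log units; within the scatter). Set beside the earlier step, the change carries from one core to the other without a difference beyond the scatter: the same change on two cores in this assay, a 2.1-fold lower number (0.33 log units; beyond the scatter) from compound 1 to compound 3 and a 2.0-fold lower number (0.30 log units; within the scatter) from compound 2 to compound 4, 1.1-fold (0.03 log units) apart, within the scatter of two such steps. This agreement rests on two cores and one assay, with one of the two steps lying within the scatter, so it neither shows that the change will carry to further cores nor explains why the steps agree.

Open, on these data alone, is whether an ethyl group or a longer chain on this oxygen, or an amine in place of the hydroxy, would shift the number further. Also open, as far as these compounds go, is whether the step holds on a core without the lactone.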